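This account rests on a few compounds, and the source may have more. Where it says the series, first, only, none or still open, it means among the compounds named here.

Among the pyrazole-free numbers at hand, the position of compound 3 `CC(C)(C)n1nc(Oc2cc(O)ccn2)c2c(N)ncnc21` is easy to state.

In an ADME assay on microsomes from liver (Homo sapiens) for metabolic stability, read by LC-MS, using NADPH, with a stated time of 10 min, tested at 10 uM (a higher number here means that the compound lasts longer, a lower number that the compound disappears faster), compound 3 `CC(C)(C)n1nc(Oc2cc(O)ccn2)c2c(N)ncnc21` gives 1.4 h, the higher of the two actual numbers. Compound 2 `Nc1ncnc2c1c(Oc1cccc(Cl)c1)nn2[C@H]1C[C@H](F)C1` gives 0.153 h, lower by more than the scatter. Compound 1 `Nc1ncnc2c1c(Oc1cc(O)ccn1)nn2C1CCC(F)(F)CC1` is reported as > 2.41 h, which is a limit and not a number.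

The move to compound 4 `Nc1ncnc2c1c(Oc1cc(O)ccn1)nn2[C@H]1C[C@H](F)C1` is 3-fluorocyclobutyl in place of tert-butyl on an aromatic nitrogen, with the rest of compound 3 kept. Within the data shown here, one measured step bears directly on this nitrogen: an at least 1.7-fold lower number from compound 1 to compound 3 (0.23 log units; that floor lies within the scatter). It rests on (the limit of > 2.41 h in this assay, at which 1 of the 3 values shown sits), so it gives a floor and no true size. Compound 2 carries the same 3-fluorocyclobutyl and sits at 0.153 h, but it differs from compound 4 elsewhere, so it is only a weak pointer downward. The expected step in this assay is therefore small and downward, a 1.6-fold lower number from compound 3 to compound 4 (0.19 log units; within the scatter). Compound 4 is estimated at 0.9 h, with an expected range from 0.35 h to 2.2 h.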

Compound 4, half-life: 1.03 h
Estimate against measurement, compound 4: 1.1-fold (0.06 log units) below, within the range that was stated.
By their numbers in this assay, from the lowest: compound 2; then compounds 4 and 3 (each within the scatter of the next). At a limit, above all of these: compound 1.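

In this assay, with 4-hydroxypyridin-2-yl held constant, replacing tert-butyl with 3-fluorocyclobutyl on the aromatic nitrogen does not separate the two compounds: the step is a 1.4-fold lower number from compound 3 to compound 4 (0.13 log units; within the scatter). With 3-fluorocyclobutyl held constant, the change on the oxygen, 4-hydroxypyridin-2-yl in place of 3-chlorophenyl, gives a 6.7-fold higher number from compound 2 to compound 4 (0.83 log units; beyond the scatter), so the low number seen with that fluorinated group does not carry over. The step from 4,4-difluorocyclohexyl on the same nitrogen, an at least 2.3-fold lower number from compound 1 to compound 4 (0.36 log units; beyond the scatter), is a floor and no true size, and unlike the earlier floor on this nitrogen it clears the scatter, resting on a limit: the limit of > 2.41 h in this assay, at which 1 of the 4 values shown sits.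

The compounds shown leave open whether a plain cyclobutyl would hold the same half-life as 3-fluorocyclobutyl. They also leave open how a methoxy group in place of the hydroxyl of 4-hydroxypyridin-2-yl would fare.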